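Replacing 3-nitrophenyl on a carbonyl carbon

The source may report more compounds than this note shows. Statements on the series, on what has been measured and on what is new or still open speak of the compounds shown alone.

Values in a functional assay on KBVIN cells (Homo sapiens) for antiproliferative activity, read by sulforhodamine B assay, with a stated time of 3 days; on this read-out lower numbers stand for stronger inhibition of growth and higher numbers for weaker inhibition of growth:
Compound 1 `O=C(Nc1nccs1)c1cccc(Nc2ncc(F)c(Nc3ccc(F)cc3)n2)c1`: > 10000 nM, a limit
Compound 2 `O=C(Nc1ccc(C(F)(F)F)cc1)c1cccc(Nc2ncc(F)c(Nc3ccc(F)cc3)n2)c1`: > 10000 nM, a limit
Compound 3 `O=C(Nc1cccc(Nc2ncc(F)c(Nc3ccc(F)cc3)n2)c1)c1cccc([N+](=O)[O-])c1`: 11400 nM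

Going by the values given here, compound 3 is the only compound with a number, 11400 nM. The other two values sit at the limit of > 10000 nM in this assay, at which 2 of the 3 values shown sit.

Compound 4 `CN(C)CC(=O)Nc1cccc(Nc2ncc(F)c(Nc3ccc(F)cc3)n2)c1` has (dimethylamino)methyl in place of 3-nitrophenyl on a carbonyl carbon.

Among the compounds with values here, the only measured step is a step that the two limits leave unreadable from compound 1 to compound 2. Its size cannot be read, and it lies on an amide-type nitrogen, so it does not size this change. The estimate therefore rests on compound 3 at 11400 nM, and no change beyond the scatter is expected in this assay. The expected step is a 1.1-fold lower number from compound 3 to compound 4 (0.06 log units; within the scatter). For compound 4 the estimated value is 10000 nM, with an expected range of 3500 nM to 25000 nM.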

Compound 4, concentration for 50% growth inhibition: 1810 nM
Compound 4: middle estimate off by 5.5-fold (0.74 log units), on the high side, outside the stated range (below it).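

Putting (dimethylamino)methyl in place of 3-nitrophenyl on a carbonyl carbon gives, in this assay, a 6.3-fold lower number from compound 3 to compound 4 (0.80 log units; beyond the scatter), the only step shown with a number at both ends, so this position does respond to what it carries. The wider replacement on an aromatic carbon gives an at least 5.5-fold lower number from compound 1 to compound 4 (0.74 log units; beyond the scatter), which is only a bound, as compound 1 holds a limit. Compound 4 comes clear of that limit: the limit of > 10000 nM in this assay, at which 2 of the 4 values shown sit.

The compounds shown do not tell whether the difference follows the dimethylamino group or the loss of the 3-nitrophenyl ring. A morpholine, a piperidine or a longer chain ending in the same amine would separate the two.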